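Phenyl on the Saturated Ring Carbon of the Core

This account rests on a few compounds, and the source may have more. Where it says the series, first, only, none or still open, it means among the compounds named here.

Compound 1 `CN1CC(=O)N(C)c2cnc(Nc3ccc(S(N)(=O)=O)cc3)nc21` gives 495 nM in an assay on Sf9 cells for inhibition of serine/threonine-protein kinase 4 (Homo sapiens), read by luminescence and ADP-Glo, with a stated time of 1 h, in the presence of a further agent that is not named here (a lower number here means a stronger inhibitor, a higher number a weaker inhibitor), the higher of the two numbers in hand. Going by the values given here, compound 2 `CC(C)C1C(=O)N(C)c2cnc(Nc3ccc(S(N)(=O)=O)cc3)nc2N1C` gives 254 nM in this assay, and the step of a 1.9-fold lower number from compound 1 to compound 2 (0.29 log units; within the scatter) is the only measured change at this place. Compound 3 `CN1C(=O)C(c2ccccc2)N(C)c2nc(Nc3ccc(S(N)(=O)=O)cc3)ncc21` carries the change (phenyl in place of hydrogen on a saturated ring carbon). Because the step of a 1.9-fold lower number from compound 1 to compound 2 (0.29 log units; within the scatter) stayed within the scatter, a group at this place is expected to leave the number near that of compound 1 or move it slightly lower. Compound 3 is therefore estimated at 320 nM, with a range from 110 nM to 950 nM, which means an expected step of a 1.5-fold lower number from compound 1 to compound 3 (0.19 log units; within the scatter).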

Compound 3, half-maximal inhibitory concentration: 383 nM
Compound 3: middle estimate off by 1.2-fold (0.08 log units), on the low side; the range from low to high includes it.
By their numbers in this assay, from the lowest: compounds 2, 3 and 1 (each within the scatter of the next).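

In this assay, phenyl in place of hydrogen on this saturated ring carbon gives (a 1.3-fold lower number from compound 1 to compound 3 (0.11 log units; within the scatter)), so an aromatic ring of carbon can stand here without moving the number beyond the scatter. Phenyl in place of isopropyl gives (a 1.5-fold higher number from compound 2 to compound 3 (0.18 log units; within the scatter)), so compounds 1, 2 and 3 cannot be told apart at this place. No measurement bears on why this is so.

Open, going by these compounds, is whether an amine or a carboxylic acid on this carbon would also stay within the scatter of compound 1 or leave it.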